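The compounds below may be only part of what the source reports. "The series", "measured", "known", "first", "only" and "open" are said of these compounds alone.

Measured compounds:
compound 1 `CC(C)=CCN1CCCC(/C=C\c2ccccc2)C1` — 1 nM
compound 2 `C(=C\C1CCCN(CCCCc2ccccc2)C1)\c1ccccc1` — 7 nM
compound 3 `CC(C)=CCN1CCCC(/C=C/c2ccccc2)C1` — 38 nM

In an assay on isolated protein for binding affinity to Sigma non-opioid intracellular receptor 1 (Rattus norvegicus) (on this read-out lower numbers stand for stronger inhibition and higher numbers for weaker inhibition), compound 3 gives the highest number of the three. Compound 2, with an aryl-ended chain on the ring nitrogen, gives 7 nM, a lower number. For the measured compounds named here, the gap to compound 1 is the only single-point step in the set: a 38-fold higher number from compound 1 to compound 3 (1.58 log units; beyond the scatter), a change at the double bond, tied to the fact that one of compounds 1 and 3 is drawn with a defined configuration and the other without, at the place where they differ.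

Compound 4 `C(=C/C1CCCN(Cc2ccccc2)C1)\c1ccccc1` is obtained from compound 3 by phenyl in place of 2-methylprop-1-en-1-yl on a saturated chain carbon bound to an amine nitrogen in a ring. Going by the values given here, no measured step concerns this change; the one measured step alters only the double bond geometry and so does not bear on it. What remains is the other member carrying an aromatic ring on the nitrogen substituent: in this assay compound 2 gives 7 nM. On that slender basis a moderate downward step is expected, a 2.5-fold lower number from compound 3 to compound 4 (0.40 log units; beyond the scatter), with wide uncertainty. Compound 4 is estimated at 15 nM, within 3 nM to 75 nM.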

Compound 4, half-maximal inhibitory concentration: 10 nM
Compound 4: middle estimate off by 1.5-fold (0.18 log units), on the high side; measured number inside the range.
By their numbers in this assay, from the lowest: compound 1; then compounds 2 and 4 (each within the scatter of the next); then compound 3.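

In this assay, the nitrogen substituent now has a measured step of its own, with phenyl in place of 2-methylprop-1-en-1-yl giving a 3.8-fold lower number from compound 3 to compound 4 (0.58 log units; beyond the scatter) while the double bond stays as drawn in compound 3. The earlier step, a 38-fold higher number from compound 1 to compound 3 (1.58 log units; beyond the scatter), reported only on double bond geometry and is the larger of the two, so in this pair the aromatic ring shifts the number less than the geometry change did. No available evidence bears on this change at the nitrogen substituent.

On these data alone, whether the same replacement would shift the number similarly with the double bond drawn as in compound 1 remains open. Also open, as far as these compounds go, is whether the aromatic ring itself matters, which a cyclohexyl or pyridyl group at this place would test.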